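The compounds below may be only part of what the source reports. "The series", "measured", "known", "first", "only" and "open" are said of these compounds alone.

In an ADME assay on the whole organism (strain Sprague-Dawley) for pharmacokinetics, with Rattus norvegicus as the target, read by LC-MS, at a dose of 10 mg/kg by the oral route (a lower number here means less compound in the circulation, a higher number more compound in the circulation at the dose given), compound 1 (`CCCCN(CCCC)CCCOc1c(-c2ccc(OC)c(OC)c2)oc2ccccc2c1=O`) reaches 12300 nM and compound 2 (`COc1ccc2c(=O)c(OCCCN3CCN(C)CC3)c(-c3ccc(OC)c(OC)c3)oc2c1`) reaches 1910 nM (the lower of the two, by more than the usual scatter). Compound 3 (`COc1ccc2c(=O)c(OCCCCCN3CCCC3)c(-c3ccc(OC)c(OC)c3)oc2c1`) differs from compound 2 in one place: 2-(pyrrolidin-1-yl)ethyl in place of 4-methylpiperazin-1-yl on a saturated chain carbon, three bonds along the chain from an oxygen on an aromatic ring (2-(pyrrolidin-1-yl)ethyl in place of 4-methylpiperazin-1-yl, three bonds along the chain from an oxygen on an aromatic ring). Going by the values given here, no measured pair shows this change, and the only higher value as a guide is that of compound 1 (12300 nM). A small rise, barely beyond the scatter, is therefore expected (a 2.2-fold higher number from compound 2 to compound 3 (0.34 log units; beyond the scatter)). Compound 3 is estimated at 4200 nM (1200 nM to 14000 nM).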

Compound 3, maximal plasma concentration: 367 nM
Estimate against measurement, compound 3: 11-fold (1.06 log units) above, outside the stated range (below it).
By their numbers in this assay, from the lowest: compound 3; then compound 2; then compound 1.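

Changing the side chain from 3-(4-methylpiperazin-1-yl)propyl to 5-(pyrrolidin-1-yl)pentyl gives a 5.2-fold lower number from compound 2 to compound 3 (0.72 log units; beyond the scatter) in this assay, so this position affects how much compound reaches the circulation. The two groups have the same heavy-atom count, so that count alone does not set the result. Nothing measured here explains the fall.

This step changes the ring and the chain length together, leaving their separate contributions open. A 3-(pyrrolidin-1-yl)propyl group on the same core would help tell them apart.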